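Swapping an ethoxy for a butylsulfanyl on the shared core

A few compounds are considered here, and "the series" means these few. Any claim that something is new, unique, unknown or untested is made for them only; others in the source may bear on it.

Compound 1 `CCOc1nc(N)nc2c1ncn2/C=C1/CC1(CO)CO` gives in an ADME assay on BCBL1 cells (Homo sapiens) for cytotoxicity, with a stated time of 7 days (a lower number here means that less compound is tolerated, a higher number that more compound is tolerated), the value > 20000 nM, which is a limit of the assay and not a number.
Compound 2 `CCCCCOc1nc(N)nc2c1ncn2/C=C1/CC1(CO)CO` gives in this assay the value > 20000 nM, again a limit of the assay.

Compound 1 thus stands at the limit of > 20000 nM in this assay, at which 2 of the 2 values shown sit. The step that the two limits leave unreadable from compound 1 to compound 2 cannot be read, since both ends are limits. Compound 3 `CCCCSc1nc(N)nc2c1ncn2/C=C1/CC1(CO)CO` differs from compound 1 by butylsulfanyl in place of ethoxy on an aromatic carbon. Among the compounds with values here, no measured step speaks to this change, as the only one is unreadable. In this assay compound 3 is expected to remain at the same limit, so the estimated step is a step that the limit leaves unreadable from compound 1 to compound 3. The estimated value for compound 3 is 30000 nM, between 8000 nM and 100000 nM.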

Compound 3, half-maximal cytotoxic concentration: > 20000 nM
Compound 3: a limit, no number; the forecaster's own chance of this, stated with the estimate: 70%; the middle value is on the limit's open side.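

No step can be read among compound 1, compound 2 and compound 3, because all three sit at the same limit of the assay: the limit of > 20000 nM in this assay, at which 3 of the 3 values shown sit.

The compounds shown leave open whether ethoxy, pentyloxy and butylsulfanyl differ at all in this assay.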